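This account rests on a few compounds, and the source may have more. Where it says the series, first, only, none or still open, it means among the compounds named here.

The account begins with compound 1 `Nc1ccc2c(c1)/C(=C1\C(=O)Nc3ccccc31)C(=O)N2` and its close relative compound 2 `O=C1Nc2cc([N+](=O)[O-])ccc2/C1=C1/Nc2ccccc2C1=O`, both assessed in a functional assay on Caco-2 cells (Homo sapiens) for antiproliferative activity, with a stated time of 72 h; on this read-out higher numbers stand for weaker inhibition and lower numbers for stronger inhibition. Compound 1 stands at the edge of what the measurement resolves: in this assay compound 1 reaches only the limit of > 25000 nM, a boundary rather than a number. That position is recorded in the evidence as the limit of > 25000 nM in this assay, at which 1 of the 2 values shown sits. Within the data shown here, by contrast, compound 2 in this assay gives 3000 nM, a real value; no single-point step connects compound 2 to compound 1, so the two are noted only for what each shows.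

From compound 1 the path leads to compound 3 `O=C1Nc2ccccc2/C1=C1\C(=O)Nc2ccc([N+](=O)[O-])cc21`, which has yet to be tested in this assay. The change is counted as nitro in place of amino on an aromatic carbon. Among the measured compounds shown here, no measured step between compounds differing in one place is available to anchor the size of this move, so any expectation rests on the values of compounds 1 and 2 alone.

Given that compound 2, which carries the nitro group, shows a real value of 3000 nM, compound 3 is expected to come in at 4000 nM, within a range of 1000 nM to 20000 nM. The expected step is an at least 6.2-fold lower number from compound 1 to compound 3 (0.79 log units; beyond the scatter), a gain in inhibition well beyond the usual scatter, though a reported limit remains possible.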

Compound 3, half-maximal inhibitory concentration: > 25000 nM
Compound 3 gave a limit, no number; the forecaster's own chance of this, stated with the estimate: 25%; middle value at least 6.2-fold (0.79 log units) from the limit.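

In this assay, among these compounds, compound 3 gives > 25000 nM, a limit and not a number, and compound 1 also stands at a limit, so no step from compound 1 to compound 3 can be read. The compounds shown leave open how far, if at all, nitro in place of amino on an aromatic carbon changes antiproliferative activity.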